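Mirror-image question for the chloro compound

A few compounds are considered here, and "the series" means these few. Any claim that something is new, unique, unknown or untested is made for them only; others in the source may bear on it.

Measured in a functional assay on A-431 cells (Homo sapiens) for antiproliferative activity, read by sulforhodamine B assay, with a stated time of 72 h; on this read-out lower numbers stand for stronger inhibition and higher numbers for weaker inhibition:
- Compound 1 `C=C1C[C@](CBr)(c2ccccc2)OC1=O`: 1330 nM
- Compound 2 `C=C1C[C@](CCl)(c2ccccc2)OC1=O`: 30600 nM

Among the compounds with values here, of the two measured compounds, compound 2 has the higher number at 30600 nM, and compound 1 is its only neighbour. Compound 3 `C=C1C[C@@](CCl)(c2ccccc2)OC1=O` has not yet been measured and differs from compound 2 only in configuration: the two compounds have the same atoms and bonds and differ only in configuration as drawn: 1 of 1 stereo elements differ; a stereocentre at a saturated ring carbon is drawn R in compound 2 and S in compound 3. A stereocentre at a saturated ring carbon is drawn R in compound 2 and S in compound 3.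

Within the data shown here, the only measured step is a 23-fold higher number from compound 1 to compound 2 (1.36 log units; beyond the scatter), a large one. It places chloro where bromo stood and leaves the configuration as drawn, so it does not bear directly on this change. Among the measured compounds shown here, no measured pair differs in configuration alone, which leaves both the size and the direction of the change in this assay open. No step beyond the scatter is therefore predicted, although one cannot be ruled out, and the range is kept wide.

The expected step is a 1.4-fold lower number from compound 2 to compound 3 (0.14 log units; within the scatter). For compound 3 the estimated value is 22000 nM, with an expected range from 7000 nM to 70000 nM.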

Compound 3, half-maximal inhibitory concentration: 43000 nM
Compound 3: middle estimate off by 2.0-fold (0.29 log units), on the low side; the range from low to high includes it.
By their numbers in this assay, from the lowest: compound 1; then compounds 2 and 3 (each within the scatter of the next).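

In this assay, changing the stereocentre at a saturated ring carbon from R to S gives a 1.4-fold higher number from compound 2 to compound 3 (0.15 log units; within the scatter), so with chloro on the chain, the drawn configuration makes no difference that can be told from the scatter. Within the data shown here, this is the first comparison that isolates configuration at this position, with nothing else changing: the fact that compounds 2 and 3 differ only in the configuration as drawn. Of the steps now available, only the halogen exchange, a 23-fold higher number from compound 1 to compound 2 (1.36 log units; beyond the scatter), lies beyond the scatter, and compound 2 and compound 3 both remain weak inhibitors on this read-out beside compound 1 at 1330 nM.

Whether configuration is equally silent with bromo on the chain stays open, as the compounds shown include no mirror-image partner of compound 1, and the result for the chloro pair cannot be carried over to the more active bromo compound. Also open, going by these compounds, is what an amine, a hydroxyl group or an iodo group would give in place of the halogen on the saturated chain carbon, and whether either configuration would then matter.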